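Step from compound 2 to compound 4 at the melanin-concentrating hormone receptor

The source may report more compounds than this note shows. Statements on the series, on what has been measured and on what is new or still open speak of the compounds shown alone.

The measured compounds are compound 1 `O=C(CCc1ccc(C(F)(F)F)cc1)Nc1ccc2nc(N3CC4CC3CN4)ccc2c1` with 210 nM, compound 2 `CN(c1ccc2cc(NC(=O)CCc3ccc(C(F)(F)F)cc3)ccc2n1)C1CCCC1` with 2 nM and compound 3 `CC(C)C(=O)NC1CCN(c2ccc3cc(NC(=O)CCc4ccc(C(F)(F)F)cc4)ccc3n2)C1` with 1 nM, all in an assay on isolated protein for displacement of a labelled ligand from melanin-concentrating hormone receptor 1 (Homo sapiens); on this read-out lower numbers stand for stronger inhibition and higher numbers for weaker inhibition.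

Compound 2 stands second highest of the three numbers. Its nearest neighbour is compound 3, reached by a 2.0-fold lower number from compound 2 to compound 3 (0.30 log units; within the scatter); its furthest is compound 1, from which compound 2 is reached by a 110-fold lower number from compound 1 to compound 2 (2.02 log units; beyond the scatter).

Compound 4 `NC1CCN(c2ccc3cc(NC(=O)CCc4ccc(C(F)(F)F)cc4)ccc3n2)C1` has not been measured. It differs from compound 2 in one place: 3-aminopyrrolidin-1-yl in place of cyclopentyl(methyl)amino on an aromatic carbon. Among the compounds with values here, the measured step that bears most on it is the one in which compound 2 becomes compound 3, where a substituted pyrrolidine also takes the place of the cyclopentyl(methyl)amino group and the number hardly moves, a 2.0-fold lower number from compound 2 to compound 3 (0.30 log units; within the scatter). Within the data shown here, the large step from compound 1 to compound 2, a 110-fold lower number from compound 1 to compound 2 (2.02 log units; beyond the scatter), shows that this position can carry a very large change, but compound 1 bears two rings there and no single measured step matches the entry of a bare 3-aminopyrrolidin-1-yl group. Compound 4 is therefore expected to stay close to compound 2, with a shift of a 2.5-fold higher number from compound 2 to compound 4 (0.40 log units; beyond the scatter) in this assay. The estimate for compound 4 is 5 nM, with a range from 1 nM to 30 nM.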

Compound 4, half-maximal inhibitory concentration: 12 nM
Beside the measured number, compound 4's estimate is 2.4-fold (0.38 log units) below it; low and high end bracket the measured number.
By their numbers in this assay, from the lowest: compounds 3 and 2 (each within the scatter of the next); then compound 4; then compound 1.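

In this assay, the bare 3-aminopyrrolidin-1-yl group does not hold the level of the cyclopentyl(methyl)amino group: the change brings a 6.0-fold higher number from compound 2 to compound 4 (0.78 log units; beyond the scatter), whereas the earlier exchange of that group for a substituted pyrrolidine had stayed within the scatter. What hangs on the amine nitrogen proves to count for more than the pyrrolidine ring itself, as putting hydrogen in place of isopropylcarbonyl gives a 12-fold higher number from compound 3 to compound 4 (1.08 log units; beyond the scatter), while the loss covers only part of the distance to the two-ring group of compound 1, with an 18-fold lower number from compound 1 to compound 4 (1.24 log units; beyond the scatter). No measurement shown here offers an explanation for these shifts.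

The compounds shown leave open whether a smaller acyl group such as acetyl on the amine nitrogen would return the number to the level of compound 3, or whether a simple methyl group there would do the same. They also leave open how a 3-(dimethylamino)pyrrolidin-1-yl group or a 4-aminopiperidin-1-yl group would compare with the 3-aminopyrrolidin-1-yl group on this aromatic carbon.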